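The compounds below may be only part of what the source reports. "The series", "measured", "known", "first", "only" and "open" are said of these compounds alone.

In a functional assay on CEM-DNR-bulk cells (Homo sapiens), read by MTT assay, with a stated time of 72 h (on this read-out lower numbers stand for stronger inhibition and higher numbers for weaker inhibition), compound 3 (`CNc1ncnc2c1c(-c1ccsc1)cn2[C@@H]1O[C@H](CO)[C@@H](O)[C@H]1O`) gives > 20000 nM, which is a limit of the assay and not a number. Compound 2 (`CNc1ncnc2c1c(-c1ccoc1)cn2[C@@H]1O[C@H](CO)[C@@H](O)[C@H]1O`) also gives only a limit, > 20000 nM. For the measured compounds named here, the one measured step, a step that the two limits leave unreadable from compound 2 to compound 3, therefore offers no readable size to carry forward. Compound 1 (`COc1ncnc2c1c(-c1cc3ccccc3o1)cn2[C@@H]1O[C@H](CO)[C@@H](O)[C@H]1O`), which bears 1-benzofuran-2-yl, gives a real number, 10800 nM. Compound 4 (`CNc1ncnc2c1c(-c1cc3ccccc3o1)cn2[C@@H]1O[C@H](CO)[C@@H](O)[C@H]1O`) has 1-benzofuran-2-yl in place of thiophen-3-yl on an aromatic carbon. A move toward stronger inhibition is expected because compound 1 with that same group gives 10800 nM. Its size is uncertain, and the expected step is an at least 2.2-fold lower number from compound 3 to compound 4 (0.34 log units; beyond the scatter). For compound 4 the estimated value is 9000 nM, within an expected range of 3000 nM to 20000 nM.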

Compound 4, half-maximal inhibitory concentration: > 20000 nM
Compound 4 ended at the assay's limit (the forecaster's own chance of this, stated with the estimate: 30%); middle value at least 2.2-fold (0.34 log units) away from the limit.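

Compound 4 also gives only a limit of the assay, not a number, so 1-benzofuran-2-yl on the shared core does not lift a methylamino compound into the readable range of this assay. For the compounds shown here, the one readable step, with methylamino in place of methoxy, is an at least 1.8-fold higher number from compound 1 to compound 4 (0.26 log units; that floor lies within the scatter), so this change cannot yet be called a real loss. The steps from compound 2 and compound 3 to compound 4 cannot be read, as each pair holds only limits: the limit of > 20000 nM in this assay, at which 3 of the 4 values shown sit.

Still open, going by these compounds, is how a phenyl group would read in place of 1-benzofuran-2-yl. Also open, on these data alone, is how dimethylamino would read in place of methylamino or methoxy.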